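This account rests on a few compounds, and the source may have more. Where it says the series, first, only, none or still open, it means among the compounds named here.

Compound 1 `Oc1cccc(-c2cc(-c3ccccc3)cc(-c3ccsc3)n2)c1` is one of three compounds already measured in a functional assay on DU-145 cells (Homo sapiens) for cytotoxicity, read by ELISA, with a stated time of 2 days; a higher number here means a weaker inhibitor, a lower number a stronger inhibitor; in it compound 1 gives 11700 nM. Compound 2 `Oc1ccc(-c2cc(-c3ccccc3)cc(-c3ccsc3)n2)cc1` carries the change (4-hydroxyphenyl in place of 3-hydroxyphenyl on an aromatic carbon), and in this assay compound 2 gives 8500 nM. The step that this change made is a 1.4-fold lower number from compound 1 to compound 2 (0.14 log units; within the scatter), so the two hydroxyphenyl arrangements are not told apart by this pair. Compound 3 `Oc1cccc(-c2cc(-c3ccccc3)nc(-c3ccco3)c2)c1` rests on a different core; how its core differs from that of compound 1 is not broken down here. In this assay compound 3 gives 34900 nM, the highest of the three numbers, beyond the scatter from both compound 1 and compound 2.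

Compound 4 `Oc1ccc(-c2cc(-c3ccccc3)nc(-c3ccco3)c2)cc1` has not yet been measured. It differs from compound 3 by 4-hydroxyphenyl in place of 3-hydroxyphenyl on an aromatic carbon. Among the compounds with values here, this is the same kind of change as the one from compound 1 to compound 2, but not the same: there the place was next to the ring nitrogen, meta to a phenyl group and meta to a thiophen-3-yl group, whereas here it is opposite the ring nitrogen, meta to a furan-2-yl group and meta to a phenyl group. Within the data shown here, only the one earlier pair shows the change, and its step of a 1.4-fold lower number from compound 1 to compound 2 (0.14 log units; within the scatter) lay within the scatter. He therefore expects a step of about a 1.3-fold lower number from compound 3 to compound 4 (0.13 log units; within the scatter), resting on a 1.4-fold lower number from compound 1 to compound 2 (0.14 log units; within the scatter), and because compound 3 gives 34900 nM he estimates that compound 4 will give 26000 nM in this assay, most likely between 12000 nM and 60000 nM.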

Compound 4, half-maximal inhibitory concentration: 8600 nM
Beside the measured number, compound 4's estimate is 3.0-fold (0.48 log units) above it; the measured number lies below the stated range.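

In this assay, 4-hydroxyphenyl in place of 3-hydroxyphenyl gave a 4.1-fold lower number from compound 3 to compound 4 (0.61 log units; beyond the scatter), so on the core of compound 3 the two hydroxyphenyl arrangements are told apart, with compound 4 the stronger inhibitor of that pair. Set beside the earlier pair, the change did not carry over in size from one core to the other: the same change on two cores in this assay, a 1.4-fold lower number (0.14 log units; within the scatter) from compound 1 to compound 2 and a 4.1-fold lower number (0.61 log units; beyond the scatter) from compound 3 to compound 4, 2.9-fold (0.47 log units) apart, beyond the scatter of two such steps

This does not show a shared trend across the two cores, as the earlier step lay within the scatter and so gives no firm direction to compare, and two pairs are too few to show how the change behaves across the series in general. Nor does it show what sets the steps apart, as the two cores differ both in where the hydroxyphenyl group sits on the nitrogen-containing ring and in carrying thiophen-3-yl or furan-2-yl.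

As far as these compounds go, whether the larger step goes with the furan-2-yl group or with the place opposite the ring nitrogen stays open, as does the size of the step on any third core. From the compounds shown here alone, what an amine or a carboxylic acid would do in place of the hydroxy group on that phenyl ring also remains open.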